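Swapping Naphthyl for Chlorophenyl: Expected Drop in Inhibition

A few compounds are considered here, and "the series" means these few. Any claim that something is new, unique, unknown or untested is made for them only; others in the source may bear on it.

Measured compounds:
compound 1 `COc1cc(C2CC(c3ccc(Br)cc3)=NN2C(C)=O)ccc1OCc1cn(Cc2ccc([N+](=O)[O-])cc2)nn1`: 17%
compound 2 `COc1cc(C2CC(c3cccc4ccccc34)=NN2C(C)=O)ccc1OCc1cn(Cc2ccc([N+](=O)[O-])cc2)nn1`: 95%

In a functional assay on A549 cells (Homo sapiens) for inhibition, read by sulforhodamine B assay, tested at 100 uM (on this read-out higher numbers stand for more inhibition of growth at the one concentration tested and lower numbers for less inhibition of growth), compound 1 gives 17% and compound 2 gives 95%. Compound 2 thus stands highest of the two numbers. Among the measured compounds shown here, the only measured step is a number 78 percentage points higher from compound 1 to compound 2 (beyond the scatter), a large rise beyond the scatter. Compound 3 `COc1cc(C2CC(c3ccc(Cl)cc3)=NN2C(C)=O)ccc1OCc1cn(Cc2ccc([N+](=O)[O-])cc2)nn1` differs from compound 2 by 4-chlorophenyl in place of naphthalen-1-yl on a carbon with a double bond to nitrogen. This change runs opposite to the measured step, and the entering 4-chlorophenyl is close kin to the 4-bromophenyl of compound 1, whose value is 17%. A large fall, a number 73 percentage points lower from compound 2 to compound 3 (beyond the scatter), is therefore expected. Compound 3 is estimated at 22%, within 5% to 50%.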

Compound 3, percent growth inhibition at one concentration: 0%
Compound 3: middle estimate off by 22 percentage points, on the high side; the whole stated range lies above it.
By their numbers in this assay, from the lowest: compound 3; then compound 1; then compound 2.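

Replacing naphthalen-1-yl with 4-chlorophenyl gives a number 95 percentage points lower from compound 2 to compound 3 (beyond the scatter), so at this carbon the single ring with its halogen does not keep the growth inhibition that the two-ring group gave. The halogen matters as well: chloro in place of bromo on an aromatic carbon gives a number 17 percentage points lower from compound 1 to compound 3 (beyond the scatter), a modest step, though both compounds remain far below compound 2.

From the compounds shown here alone, how a plain phenyl, a 4-methoxyphenyl or a naphthalen-2-yl group would read at this carbon remains open. Nothing available gives a reason for these steps.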